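From Isopropyl to 4-(Trifluoromethyl)phenyl on the Amide Aryl Ring

The source may hold more compounds than are shown below. What is called first, only, known or untested is meant among the compounds shown, and "the series" means these compounds.

Compound 1 `O=C(O)CCc1cccc2c1B(O)OC2`: > 100000 nM
Compound 2 `Cc1ccc(NC(=O)CCc2cccc3c2B(O)OC3)cc1`: 4500 nM
Compound 3 `CC(C)c1cccc(NC(=O)CCc2cccc3c2B(O)OC3)c1`: 1600 nM

In a functional assay on HCT-116 cells (Homo sapiens) for antiproliferative activity, read by MTT assay, with a stated time of 72 h (on this read-out lower numbers stand for stronger inhibition and higher numbers for weaker inhibition), compound 1 gives only a limit, > 100000 nM. Compound 2 gives 4500 nM in this assay. Compound 3 gives 1600 nM, the lowest of the two numbers, with compound 2 sitting above it by a gap beyond the scatter. Compound 4 `O=C(CCc1cccc2c1B(O)OC2)Nc1cccc(-c2ccc(C(F)(F)F)cc2)c1` carries 4-(trifluoromethyl)phenyl in place of isopropyl on an aromatic carbon. Within the data shown here, no measured pair traces this change, so the expected step rests on the spread seen between compound 2 and compound 3. The step from compound 3 to compound 4 is expected to be small in this assay, a 1.6-fold lower number from compound 3 to compound 4 (0.20 log units; within the scatter), within or near the scatter. Compound 4 is estimated at 1000 nM, between 300 nM and 4000 nM.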

Compound 4, half-maximal inhibitory concentration: 550 nM
Compound 4: the middle estimate sits 1.8-fold (0.26 log units) above what was measured, and the stated range covers the measured number.
By their numbers in this assay, from the lowest: compound 4; then compound 3; then compound 2. At a limit, above all of these: compound 1.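

Among these compounds, at this aromatic carbon, meta to a large group, a six-membered aromatic ring is accepted in place of a small alkyl group, which the earlier compounds did not show. In this assay, 4-(trifluoromethyl)phenyl in place of isopropyl gives a 2.9-fold lower number from compound 3 to compound 4 (0.46 log units; beyond the scatter) and so the larger group does not cost activity here. Nothing among the data shown accounts for this step.

From the compounds shown here alone, whether the ring or its trifluoromethyl carries the step stays open. So does what an unsubstituted phenyl, a pyridine or an amine would do at this carbon.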